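The source may report more compounds than this note shows. Statements on the series, on what has been measured and on what is new or still open speak of the compounds shown alone.

In a functional assay on HCT-116 cells (Homo sapiens) for cytotoxicity, read by MTT assay; on this read-out higher numbers stand for weaker inhibition and lower numbers for stronger inhibition:
Compound 1 `Cc1cc(O)c(C(=O)/C=C/c2ccccc2)c(=O)o1`: > 100000 nM (a limit)
Compound 2 `Cc1cc(O)c(C(=O)/C=C/c2ccc(F)cc2)c(=O)o1`: > 100000 nM (a limit)
Compound 3 `Cc1cc(O)c(C(=O)/C=C/c2ccc(F)c(F)c2)c(=O)o1`: 74900 nM

Compound 2 has no exact number, only a limit: compound 2 gives > 100000 nM. This is the limit of > 100000 nM in this assay, at which 2 of the 3 values shown sit. Compound 4 `Cc1cc(O)c(C(=O)/C=C/c2ccc(Cl)cc2)c(=O)o1` differs from compound 2 by one change: chloro in place of fluoro on an aromatic carbon. Among the measured compounds shown here, two measured steps bear on it, both fluoro in place of hydrogen on an aromatic carbon. One is a step that the two limits leave unreadable from compound 1 to compound 2, and the other is an at least 1.3-fold lower number from compound 2 to compound 3 (0.12 log units; that floor lies within the scatter). Neither has a readable size beyond the scatter, and neither involves chloro, so no step beyond the scatter is expected in this assay. The expected step is an at least 1.1-fold lower number from compound 2 to compound 4 (0.04 log units; that floor lies within the scatter). For compound 4 the estimate is 90000 nM, with an expected range of 40000 nM to 200000 nM.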

Compound 4, half-maximal inhibitory concentration: 87400 nM
For compound 4 the middle estimate is 1.0-fold (0.01 log units) above the measured one; the range from low to high includes it.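

In this assay, chloro on this aromatic carbon gives an exact reading, whereas hydrogen and fluoro there give only limits. Chloro in place of fluoro gives an at least 1.1-fold lower number from compound 2 to compound 4 (0.05 log units; that floor lies within the scatter), and chloro in place of hydrogen gives an at least 1.1-fold lower number from compound 1 to compound 4 (0.05 log units; that floor lies within the scatter). Each of these is only a floor, and the true size of the steps remains unknown, since compound 1 and compound 2 each stand as a limit: the limit of > 100000 nM in this assay, at which 2 of the 4 values shown sit.

Still open, going by these compounds, is whether a different group at this place, such as a methoxy group, trifluoromethyl or an amine, would bring a step beyond the scatter.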